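Chloro for hydroxy on a weakly cytotoxic indolinone pair

This account rests on a few compounds, and the source may have more. Where it says the series, first, only, none or still open, it means among the compounds named here.

Of the compounds shown here, two from this series have been tested in a functional assay on cells (Cancer cell lines, Homo sapiens) for cytotoxicity, with a stated time of 48 h; a higher number here means a weaker inhibitor of growth, a lower number a stronger inhibitor of growth. Compound 1 `COc1cc2c(/C=C3/C(=O)Nc4ccc(O)cc43)c(Cl)n(Cc3cc(OC)c(OC)c(OC)c3)c2cc1C` gives 43700 nM in this assay. Compound 2 `O=C1Nc2ccccc2/C1=C\c1c(Cl)n(Cc2ccccc2)c2ccccc12` gives 66100 nM in this assay, a number that sits within the usual scatter of the result for compound 1, so the two cannot be told apart on these data. Compound 3 `COc1cc2c(/C=C3/C(=O)Nc4ccc(Cl)cc43)c(Cl)n(Cc3cc(OC)c(OC)c(OC)c3)c2cc1C` has not yet been measured. It differs from compound 1 by a single change: chloro in place of hydroxy on an aromatic carbon. Among the compounds with values here, no pair of measured compounds shows this exchange, so there is no step to lean on. Given that compound 1 gives 43700 nM, the step expected in this assay from compound 1 to compound 3 is a 1.1-fold lower number from compound 1 to compound 3 (0.04 log units; within the scatter), no larger than the scatter and in no firm direction. Compound 3 is therefore estimated at 40000 nM in this assay, within a range from 12000 nM to 130000 nM.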

Compound 3, concentration for total growth inhibition: 13800 nM
Estimate against measurement, compound 3: 2.9-fold (0.46 log units) above; low and high end bracket the measured number.
By their numbers in this assay, from the lowest: compound 3; then compounds 1 and 2 (each within the scatter of the next).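

In this assay, within the data shown here, chloro in place of hydroxy on this aromatic carbon gives a 3.2-fold lower number from compound 1 to compound 3 (0.50 log units; beyond the scatter), the only step between compounds differing in one place so far. It shows that the number responds to the group at this position and that growth inhibition in this assay does not depend on the hydroxy group there, since compound 3 gives 13800 nM without it. No measurement shown explains the step.

With a single pair, the compounds shown cannot separate the loss of hydroxy from the arrival of chloro, and they do not show whether the step would hold on another core. On these data alone, how an amine, a carboxylic acid or bromo would behave at this position also remains open.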